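The source may report more compounds than this note shows. Statements on the series, on what has been measured and on what is new or still open speak of the compounds shown alone.

Among the compounds with values here, in an ADME assay on microsomes (Homo sapiens) for metabolic stability (a lower number here means that the compound disappears faster, a higher number that the compound lasts longer), compound 1 `O=C(c1ccccc1)N1CCC(C(=O)N2N=CCC2c2ccccc2)CC1` gives 1.72 h, the only plain number in this small set. Compound 2 `O=C(C1CCN(C(=O)C(F)(F)F)CC1)N1N=CCC1c1ccccc1` gives > 1.5 h, which is a limit of the assay and not a number. Compound 3 `O=C(C1CCN(c2ccccc2)CC1)N1N=CCC1c1ccccc1` likewise stands only at a limit, > 1.5 h. Together these make up (the limit of > 1.5 h in this assay, at which 2 of the 3 values shown sit).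

Compound 4 `O=C(c1c[nH]nn1)N1CCC(C(=O)N2N=CCC2c2ccccc2)CC1` carries (1H-1,2,3-triazol-4-yl)carbonyl in place of phenyl on an amine nitrogen in a ring.

Within the data shown here, three measured steps bear on this change: a step that the limit leaves unreadable from compound 1 to compound 3, a step that the two limits leave unreadable from compound 2 to compound 3 and a step that the limit leaves unreadable from compound 1 to compound 2. None of them has a readable size, so they give no ground for expecting a step beyond the scatter in either direction in this assay. The best anchor is compound 1, which also has a carbonyl on that nitrogen and gives 1.72 h.

The expected step is a step that the limit leaves unreadable from compound 3 to compound 4, with no clear change anticipated. For compound 4 the estimated half-life is 1.8 h, with an expected range of 0.9 h to 3.5 h.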

Compound 4, half-life: > 2.75 h
Compound 4 ended at the assay's limit; the forecaster's own chance of this, stated with the estimate: 50%; middle value at least 1.5-fold (0.18 log units) from the limit.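

In this assay, within the data shown here, the change of phenyl to 1H-1,2,3-triazol-4-yl on the carbonyl carbon gives the first step in this set with a readable floor: an at least 1.5-fold higher number from compound 1 to compound 4 (0.20 log units; that floor lies within the scatter). The five-membered aromatic ring with its 3 hetero atoms therefore leaves no sign of a shorter half-life than the phenyl of compound 1, although that floor alone does not establish a gain beyond the scatter. The value of compound 4 is itself a limit and not a number: the limit of > 2.75 h in this assay, at which 1 of the 4 values shown sits.

On these data alone, the steps joining compound 4 to compound 2 and compound 3 cannot be read, so its order relative to those two stays open. Also open, as far as these compounds go, is how an amine or a carboxylic acid on that carbonyl carbon would behave in this assay.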